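Anilide in place of acid on an oxadiazole propanoate

The source may report more compounds than this note shows. Statements on the series, on what has been measured and on what is new or still open speak of the compounds shown alone.

Compound 1 `CC(=O)Nc1ccc(Cc2noc(CCC(=O)O)n2)cc1`: 75.3%
Compound 2 `CC(=O)Nc1ccc(Cc2noc(CCC(=O)Nc3ccc(C(F)(F)F)cc3)n2)cc1`: 37%

In a functional assay on the whole organism (strain C57BL/6) for inhibition, with Mus musculus as the target, read by paw edema, with stated times of 1 h and 4 h, at a dose of 100 mg/kg by the oral route (on this read-out lower numbers stand for less inhibition and higher numbers for more inhibition at the one dose given (going by the name of the read-out)), compound 1 gives 75.3%, the higher of the two numbers; compound 2 gives 37%, a gap beyond the usual scatter. Compound 3 `C#Cc1cccc(NC(=O)CCc2nc(Cc3ccc(NC(C)=O)cc3)no2)c1` differs from compound 1 by (3-ethynylphenyl)amino in place of hydroxy on a carbonyl carbon. Since the step between the measured compounds is not one of single change, the expectation rests on the compound 2 value: a sizeable drop is expected, because in this assay compound 2 gives 37%. The expected step of a number 35.3 percentage points lower from compound 1 to compound 3 (beyond the scatter) goes down. For compound 3 the estimate in this assay is 40%, between 20% and 60%.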

Compound 3, a percentage reported as inhibition, in the whole organism at one dose (the size of the read-out at that dose, not a potency): 84.9%
Estimate against measurement, compound 3: 44.9 percentage points below, and the stated range ends below it.
By their numbers in this assay, from the lowest: compound 2; then compounds 1 and 3 (each within the scatter of the next).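

In this assay, replacing the acid's hydroxy on this carbonyl carbon with an aryl amide need not lower the read-out: (3-ethynylphenyl)amino gives a number 9.6 percentage points higher from compound 1 to compound 3 (within the scatter). The aryl group on the amide-type nitrogen matters far more, since 3-ethynylphenyl in place of 4-(trifluoromethyl)phenyl gives a number 47.9 percentage points higher from compound 2 to compound 3 (beyond the scatter). Nothing measured here explains this difference. Still open, from the compounds shown here alone, is how an unsubstituted phenyl group on that nitrogen would compare, which would help show whether the ethynyl or the trifluoromethyl group drives the gap. A methyl ester in place of the acid is also untested in these data.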